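From a Methyl Amide to a Pyridyl Amide

The source may hold more compounds than are shown below. What is called first, only, known or untested is meant among the compounds shown, and "the series" means these compounds.

Two compounds sharing one core have been run in a functional assay on the whole organism with Mus musculus as the target; on this read-out higher numbers stand for an effect only at larger amounts of compound and lower numbers for an effect already at smaller amounts. Compound 1 `CN(C)C(=O)Cn1c(-c2ccsc2)nc2cccnc21` gives 38 mg/kg in this assay. Compound 2 `CNC(=O)Cn1c(-c2ccc(Cl)cc2)nc2cccnc21` gives 12.5 mg/kg, the lowest of the two numbers, and its gap to compound 1 lies beyond the usual scatter. The next compound, compound 3 `O=C(Cn1c(-c2ccc(Cl)cc2)nc2cccnc21)Nc1cccnc1`, differs from compound 2 in one place: pyridin-3-yl in place of methyl on an amide-type nitrogen. For the measured compounds named here, no measured pair shows this change, so nothing sets its size. For compound 3 the expected step is a 1.2-fold higher number from compound 2 to compound 3 (0.08 log units; within the scatter), not beyond the scatter. Compound 3 is estimated at 15 mg/kg, within 5 mg/kg to 45 mg/kg.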

Compound 3, dose for half-maximal effect: 100 mg/kg
Beside the measured number, compound 3's estimate is 6.7-fold (0.82 log units) below it, outside the stated range (above it).
By their numbers in this assay, from the lowest: compound 2; then compound 1; then compound 3.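

For the compounds shown here, the step of an 8.0-fold higher number from compound 2 to compound 3 (0.90 log units; beyond the scatter) in this assay is the first reading at this position, and it shows that the group on the amide-type nitrogen matters, since this one change lies beyond the scatter. Methyl sits on the side of the lower number and pyridin-3-yl on the side of the higher number, so this aromatic ring is not interchangeable with methyl here. Nothing available bears on why the number rises.

Going by these compounds, it remains open whether the ring as such or its nitrogen goes with the step, which a phenyl group on the same amide nitrogen would separate. Also open, on these data alone, is whether an ethyl group would stay close to compound 2.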